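Fluorophenyl placement in a small amide series

A few compounds are considered here, and "the series" means these few. Any claim that something is new, unique, unknown or untested is made for them only; others in the source may bear on it.

Measured so far in a functional assay on the whole organism (strain Swiss) with Mus musculus as the target, in the maximal electroshock model, with a stated time of 0.25 h, at a dose of 100 mg/kg by the intraperitoneal route; on this read-out higher numbers stand for a stronger effect at the one dose given and lower numbers for a weaker effect:
compound 1 `COc1cccc(N2CCN(C(=O)C(C)N3C(=O)CCC3=O)CC2)c1` gives 25%
compound 2 `CCC(C(=O)N1CCN(c2cccc(F)c2)CC1)N1C(=O)CCC1=O` gives 0%
compound 3 `CC(C(=O)N1CCN(c2ccc(F)cc2)CC1)N1C(=O)CCC1=O` gives 75%

Compound 2 stands lowest of the three, beyond the scatter from both others. Among the measured compounds shown here, the only measured single step, a number 50 percentage points higher from compound 1 to compound 3 (beyond the scatter), concerns a different pair of groups and a different chain, so it bears on the present change only loosely; no measured pair isolates the change from compound 2 to compound 4 `CCC(C(=O)N1CCN(c2ccccc2F)CC1)N1C(=O)CCC1=O`, namely (2-fluorophenyl in place of 3-fluorophenyl on an amine nitrogen in a ring). Compound 3 shows that a fluorophenyl group on this nitrogen can go with a strong read-out, but compound 3 also differs from compound 2 in the chain. Some rise is expected, a number 25 percentage points higher from compound 2 to compound 4 (beyond the scatter), with wide uncertainty. Compound 4 is estimated at 25%, within 0% to 50%.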

Compound 4, a percentage reported as activity, at one dose (the size of the read-out at that dose, not a potency): 0%
Compound 4: middle estimate off by 25 percentage points, on the high side; the range from low to high includes it.
By their numbers in this assay, from the lowest: compounds 2 and 4 (each within the scatter of the next); then compound 1; then compound 3.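

In this assay the change from 3-fluorophenyl to 2-fluorophenyl on the amine nitrogen in a ring gives no change at the digits printed from compound 2 to compound 4 (within the scatter) and so, on the chain of compound 2, this read-out does not separate the two fluorophenyl groups. With this chain, moving the fluorine between these two placements gives no sign of a read-out at the one dose given. Nothing available bears on why this is so.

Still open, as far as these compounds go, is whether 4-fluorophenyl on the chain of compound 2 gives a read-out. Also open, from the compounds shown here alone, is how a plain phenyl or a pyridyl ring on this nitrogen behaves with either chain.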